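The compounds below may be only part of what the source reports. "The series", "measured", "known", "first", "only" and "open" are said of these compounds alone.

Compound 2 `OCCCNc1nc(-c2ccccc2)nc2c1nnn2Cc1ccccc1F` gives the lowest number of the three measured compounds in an assay on isolated protein for binding affinity to adenosine receptor A1 (Bos taurus) (on this read-out lower numbers stand for stronger inhibition and higher numbers for weaker inhibition), namely 3700000 nM. Compound 1 `CCCCCCNc1nc(-c2ccccc2)nc2c1nnn2Cc1ccccc1Cl` gives 31000000 nM and compound 3 `OCCCNc1nc(-c2ccccc2)nc2c1nnn2Cc1ccccc1Cl` gives 33000000 nM, so compound 2 sits beyond the scatter from both. Compound 4 `CCCCNc1nc(-c2ccccc2)nc2c1nnn2Cc1ccccc1F` differs from compound 2 by methyl in place of hydroxy on a saturated chain carbon, three bonds along the chain from a nitrogen on an aromatic ring. The closest guide is the step of a 1.1-fold higher number from compound 1 to compound 3 (0.03 log units; within the scatter), where hydroxy replaced propyl on a saturated chain carbon, three bonds along the chain from a nitrogen on an aromatic ring, and nothing moved beyond the scatter. The step of an 8.9-fold higher number from compound 2 to compound 3 (0.95 log units; beyond the scatter) concerns chloro in place of fluoro and does not bear directly. The expected step in this assay is therefore no change at the digits printed from compound 2 to compound 4 (within the scatter), nothing beyond the scatter. Compound 4 is estimated at 3700000 nM, with a range from 1200000 nM to 11000000 nM.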

Compound 4, inhibition constant: 4300000 nM
Compound 4: middle estimate off by 1.2-fold (0.07 log units), on the low side; the measured number falls inside the stated range.
By their numbers in this assay, from the lowest: compounds 2 and 4 (each within the scatter of the next); then compounds 1 and 3 (each within the scatter of the next).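

Keeping the fluoro group fixed, methyl in place of hydroxy at this chain carbon gives a 1.2-fold higher number from compound 2 to compound 4 (0.07 log units; within the scatter) in this assay, so the loss of the hydroxy's hydrogen-bond donor and acceptor leaves the number within the scatter. The earlier step, a 1.1-fold higher number from compound 1 to compound 3 (0.03 log units; within the scatter), swapped hydroxy for propyl, whereas this swap exchanges one heavy atom for one heavy atom. No supporting measurement bears on this result. Going by these compounds, whether an amine or a carboxylic acid at this chain carbon would stay within the scatter remains open.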